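Adding a second methoxy to compound 1

The source may report more compounds than this note shows. Statements on the series, on what has been measured and on what is new or still open speak of the compounds shown alone.

In a functional assay on A-375 cells (Homo sapiens) for inhibition, read by CCK-8 assay, with a stated time of 72 h, tested at 2 uM (a lower number here means less inhibition of growth, a higher number more inhibition of growth at the concentration tested), compound 1 (`COc1ccc(SCc2ccc(C(=O)Nc3ccccc3N)cc2)cc1`) gives 10.2%. Two relatives differ from it in one group: compound 2 (`Cc1ccc(SCc2ccc(C(=O)Nc3ccccc3N)cc2)cc1`) gives 17.5%, and compound 3 (`CC(C)(C)c1ccc(SCc2ccc(C(=O)Nc3ccccc3N)cc2)cc1`) gives 2.13%. Compound 1 cannot be told apart from either one, as the steps show: a number 7.3 percentage points higher from compound 1 to compound 2 (within the scatter) and a number 8.1 percentage points lower from compound 1 to compound 3 (within the scatter). Among the compounds with values here, the one clear step is a number 15.4 percentage points lower from compound 2 to compound 3 (beyond the scatter), which puts tert-butyl in place of methyl.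

Compound 4 (`COc1ccc(SCc2ccc(C(=O)Nc3ccccc3N)cc2)cc1OC`) keeps the core of compound 1 and makes one change: methoxy in place of hydrogen on an aromatic carbon. This is methoxy in place of hydrogen on an aromatic carbon, ortho to a methoxy group. Within the data shown here, no measured step adds a group where a hydrogen stood, so the evidence is only indirect. Swapping methoxy for methyl or tert-butyl on compound 1 stayed within the scatter, so no clear shift in this assay is expected, with perhaps a slight drop. The estimated step is a number 2.2 percentage points lower from compound 1 to compound 4 (within the scatter). Compound 4 is expected to give 8%, with an estimated range from 0% to 20%.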

Compound 4, percent growth inhibition at one concentration: 18.1%
For compound 4 the middle estimate is 10.1 percentage points below the measured one, within the range that was stated.
By their numbers in this assay, from the lowest: compounds 3, 1, 2 and 4 (each within the scatter of the next, the first and the last beyond it).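

Placing methoxy in place of hydrogen, ortho to a methoxy group, is the first change here that adds a group where a hydrogen stood, and it gives a number 7.9 percentage points higher from compound 1 to compound 4 (within the scatter) in this assay at the single concentration tested. This position therefore takes the added methoxy with no clear loss of growth inhibition, and no clear gain can be claimed either. The data shown offer no measurement that could explain this result.

Still open, as far as these compounds go, is whether a group of another kind at this position, such as an amine or a carboxylic acid, would move the number beyond the scatter. Also open, from the compounds shown here alone, is whether a longer chain, such as butoxy, would be taken here as readily as methoxy.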